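A few compounds are considered here, and "the series" means these few. Any claim that something is new, unique, unknown or untested is made for them only; others in the source may bear on it.

Compound 2 `Cn1c(-c2ccc(O)cc2)nc2c(NC3CCCC3)ncnc21` and compound 1 `CCCn1c(-c2ccccc2)nc2c(NC3CCOC3)ncnc21` share a core and differ at several places. In a functional assay on CHO cells for antagonist activity at adenosine receptor A2b (Homo sapiens), read by 33P incorporation, with a stated time of 20 min (on this read-out lower numbers stand for stronger inhibition and higher numbers for weaker inhibition), compound 1 gives 9080 nM, and compound 2 gives 17800 nM. Compound 2 stands at the top of the two numbers shown, yet its gap to compound 1 lies within the scatter, so the two cannot be told apart. Compound 3 `Cn1c(-c2ccccc2)nc2c(NC3CCCC3)ncnc21` follows from compound 2 by one change: hydrogen in place of hydroxy on an aromatic carbon. Among the measured compounds shown here, no measured pair shows this change, so only a small step is expected, a 1.5-fold lower number from compound 2 to compound 3 (0.17 log units; within the scatter), in no sure direction. Compound 3 is expected to give 12000 nM, between 4000 nM and 36000 nM.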

Compound 3, inhibition constant: 8510 nM
The estimate for compound 3 lay 1.4-fold (0.15 log units) above the measured number; low and high end bracket the measured number.
By their numbers in this assay, from the lowest: compounds 3, 1 and 2 (each within the scatter of the next, the first and the last beyond it).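

Swapping 4-hydroxyphenyl for phenyl gives a 2.1-fold lower number from compound 2 to compound 3 (0.32 log units; beyond the scatter) in this assay and is the first change here that can be read at a single place, since the earlier compounds differ at several. A modest step in this direction shows that the hydroxy, para to a large group, is not needed for the activity seen in this series. Nothing at hand explains the step.

Going by these compounds, whether a methoxy group or an amine at this same place would shift the number further remains open.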